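Hexyloxy in Place of Isobutyl on the Sulfonamide Aniline

A few compounds are considered here, and "the series" means these few. Any claim that something is new, unique, unknown or untested is made for them only; others in the source may bear on it.

The series rests on one shared core, varied at a single aromatic carbon. Compound 1 `CCc1ccc(NS(=O)(=O)c2ccc(N3CCNC3=O)cc2)cc1` carries an ethyl group there, and in a functional assay on HT-29 cells (Homo sapiens) for antiproliferative activity, read by sulforhodamine B assay, with a stated time of 48 h (a lower number here means a stronger inhibitor, a higher number a weaker inhibitor), compound 1 gives 660 nM. Compound 2 `O=C1NCCN1c1ccc(S(=O)(=O)Nc2ccc(Br)cc2)cc1` bears a bromo group instead, and in this assay compound 2 gives 300 nM; the step of a 2.2-fold lower number from compound 1 to compound 2 (0.34 log units; beyond the scatter) is a modest gain. Compound 3 `CC(C)Cc1ccc(NS(=O)(=O)c2ccc(N3CCNC3=O)cc2)cc1` has an isobutyl group at that place. In this assay compound 3 reaches only the limit of the assay, > 1000 nM, so no number is known for it (the limit of > 1000 nM in this assay, at which 1 of the 3 values shown sits). The steps of an at least 1.5-fold higher number from compound 1 to compound 3 (0.18 log units; that floor lies within the scatter) and an at least 3.3-fold higher number from compound 2 to compound 3 (0.52 log units; beyond the scatter) both run toward weaker inhibition as the alkyl group grows.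

Compound 4 `CCCCCCOc1ccc(NS(=O)(=O)c2ccc(N3CCNC3=O)cc2)cc1` differs from compound 3 by hexyloxy in place of isobutyl on an aromatic carbon. The two steps toward compound 3 are the ones that bear on this change, and both point away from potency as the substituent at this carbon grows; the hexyloxy chain is longer still. The expectation is therefore a step that the limit leaves unreadable from compound 3 to compound 4 of little or no size beyond the scatter, with compound 4 likely remaining at the limit. Compound 4 is estimated at 3000 nM in this assay, within a range of 800 nM to 15000 nM.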

Compound 4, half-maximal inhibitory concentration: > 1000 nM
Compound 4 ended at the assay's limit; the forecaster's own chance of this, stated with the estimate: 70%; the middle value does not contradict the limit.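

Hexyloxy brings to this aromatic carbon a hydrogen-bond acceptor that isobutyl lacks, yet compound 4 still stands only at a limit of this assay: the limit of > 1000 nM in this assay, at which 2 of the 4 values shown sit.

Measured against the bromo group, the step of an at least 3.3-fold higher number from compound 2 to compound 4 (0.52 log units; beyond the scatter) shows a real loss of at least modest size, so neither of the two larger groups at this carbon matches compound 2. The step of an at least 1.5-fold higher number from compound 1 to compound 4 (0.18 log units; that floor lies within the scatter) has a floor within the scatter, so it does not separate hexyloxy from ethyl, and the step between compound 3 and compound 4 cannot be read, which leaves the two groups unranked.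

The compounds shown leave open whether a short methoxy group at this carbon would return a number within the range of the assay, which would help separate the effect of the ether oxygen from that of chain length. They also leave open whether the lower number seen with bromo extends to chloro or fluoro, and how an amine or a carboxylic acid at this carbon would read.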